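Chain extension in an isothiocyanate-linked series

This account rests on a few compounds, and the source may have more. Where it says the series, first, only, none or still open, it means among the compounds named here.

Measured so far:
- compound 1 `CN(C)C(=O)c1cc2cnc(Nc3ccc(C(=O)NCCCCCCN=C=S)cc3F)nc2n1C1CCCC1` gives -11.8% in a functional assay on A549 cells (Homo sapiens) for inhibition, read by CCK-8 assay, with a stated time of 72 h, tested at 1 uM; on this read-out higher numbers stand for a stronger effect at the one concentration tested and lower numbers for a weaker effect
- compound 2 `CN(C)C(=O)c1cc2cnc(Nc3ccc(C(=O)NCCCCCCCN=C=S)cc3F)nc2n1C1CCCC1` gives 0.05% in this assay
- compound 3 `CN(C)C(=O)c1cc2cnc(Nc3ccc(NC(=O)CCCCN=C=S)cc3)nc2n1C1CCCC1` gives 38.2% in this assay

Within the data shown here, the one measured step, a number 11.9 percentage points higher from compound 1 to compound 2 (beyond the scatter), comes from a group of 4 heavy atoms (2 carbon, 1 nitrogen, 1 sulfur; no ring) in place of a group of 3 heavy atoms (1 carbon, 1 nitrogen, 1 sulfur; no ring), on a saturated chain carbon, six bonds along the chain from an amide-type nitrogen. Compound 3 stands highest of the three, beyond the scatter against both others; how its core differs from that of compound 1 is not broken down here.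

Compound 4 `CN(C)C(=O)c1cc2cnc(Nc3ccc(NC(=O)CCCCCN=C=S)cc3)nc2n1C1CCCC1` is not yet measured. It differs from compound 3 by a group of 4 heavy atoms (2 carbon, 1 nitrogen, 1 sulfur; no ring) in place of a group of 3 heavy atoms (1 carbon, 1 nitrogen, 1 sulfur; no ring), on a saturated chain carbon, four bonds along the chain from a carbonyl carbon. The place is not the same as in the earlier pair: there the group sits six bonds along the chain from an amide-type nitrogen, here four bonds along the chain from a carbonyl carbon, so this is the same kind of change, not the same change.

The earlier step was a modest rise beyond the scatter. Among the measured compounds shown here, a step of similar size is expected here, a number 9.8 percentage points higher from compound 3 to compound 4 (within the scatter), since the single precedent is a number 11.9 percentage points higher from compound 1 to compound 2 (beyond the scatter). For compound 4 in this assay the expected value is 48%, with a likely range from 30% to 65%.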

Compound 4, a percentage reported as inhibition, at one concentration (the size of the read-out at that concentration, not a potency): 56.1%
Beside the measured number, compound 4's estimate is 8.1 percentage points below it; measured number inside the range.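

In this assay the longer chain gives a number 17.9 percentage points higher from compound 3 to compound 4 (beyond the scatter), so the rise seen on the core of compound 1 also appears on the core of compound 3. Set side by side, the two steps agree in direction, and the scatter separates them in size no more than it would separate any two such steps: the same change on two cores in this assay, a number 11.9 percentage points higher (beyond the scatter) from compound 1 to compound 2 and a number 17.9 percentage points higher (beyond the scatter) from compound 3 to compound 4, 6.1 percentage points apart, within the scatter of two such steps. Among these compounds, this rests on only two pairs, with the change at a different place in each, so it does not show that the step would carry to any further core, nor does it explain why the step occurs.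

Still open, as far as these compounds go, is whether a longer chain on the core of compound 4 would raise the inhibition further or reverse it, and whether an amine or a carboxylic acid in place of the isothiocyanate would keep it. Each compound is also read at a single concentration, so these numbers tell only of a stronger or weaker effect at that concentration.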